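A few compounds are considered here, and "the series" means these few. Any claim that something is new, unique, unknown or untested is made for them only; others in the source may bear on it.

Measured in a functional assay on LNCaP cells (Homo sapiens) for antiproliferative activity, read by MTT assay, with a stated time of 24 h; on this read-out higher numbers stand for weaker inhibition and lower numbers for stronger inhibition:
- Compound 1 `COc1ccc(-c2noc(-c3ccccc3)n2)cc1OC1CCCC1`: > 1000000 nM, which is a limit.
- Compound 2 `COc1ccc(-c2noc(C3CCNCC3)n2)cc1OC1CCCC1`: 10 nM.

Within the data shown here, compound 2 holds the only true number in this assay, and its one comparison is against a limit. Compound 3 `COc1ccc(-c2noc(-c3ccc(F)cc3)n2)cc1OC1CCCC1` brings the change (4-fluorophenyl in place of piperidin-4-yl on an aromatic carbon), 4-fluorophenyl in place of piperidin-4-yl on an aromatic carbon. Among the measured compounds shown here, the one measured step bearing on this is the large at least 100000-fold lower number from compound 1 to compound 2 (5.00 log units; beyond the scatter), where piperidin-4-yl replaced phenyl. Losing piperidin-4-yl for an aryl group should largely reverse it, so a large rise towards weaker inhibition is expected, estimated as a 70000-fold higher number from compound 2 to compound 3 (4.85 log units; beyond the scatter). Compound 3 is expected at 700000 nM, with an estimated range of 50000 nM to 3000000 nM.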

Compound 3, half-maximal inhibitory concentration: 87900 nM
Compound 3: middle estimate off by 8.0-fold (0.90 log units), on the high side; the measured number falls inside the stated range.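

With this assay, this position now has a true number for an aryl group, and the step to it from piperidin-4-yl is fully measured: an 8800-fold higher number from compound 2 to compound 3 (3.94 log units; beyond the scatter). On the phenyl ring itself, fluoro in place of hydrogen also registers, as an at least 11-fold lower number from compound 1 to compound 3 (1.05 log units; beyond the scatter). That step has only a one-sided size, as compound 1 stands at a limit: the limit of > 1000000 nM in this assay, at which 1 of the 3 values shown sits.

The compounds shown leave open whether the ring nitrogen of piperidin-4-yl or its saturated ring carries the difference, which cyclohexyl or an open-chain amine would separate. Going by these compounds, how chloro or methoxy on the phenyl ring would compare also remains open.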